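Hydroxyl to methyl on the anilino ring

This account rests on a few compounds, and the source may have more. Where it says the series, first, only, none or still open, it means among the compounds named here.

Within the data shown here, compound 2, `Cn1nc(-c2ccnc(Nc3cccc(O)c3)n2)c2ccccc21`, gives 28200 nM in a functional assay on MCF7 cells (Homo sapiens) for antiproliferative activity, read by MTT assay, with a stated time of 72 h (on this read-out higher numbers stand for weaker inhibition of growth and lower numbers for stronger inhibition of growth), the highest of the two numbers so far; compound 1, `Cn1nc(-c2ccnc(Nc3ccc(O)cc3)n2)c2ccccc21`, gives 8910 nM. Among the measured compounds shown here, the one measured step, a 3.2-fold higher number from compound 1 to compound 2 (0.50 log units; beyond the scatter), is modest and beyond the scatter.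

Compound 3, `Cc1ccc(Nc2nccc(-c3nn(C)c4ccccc34)n2)cc1`, differs from compound 2 by 4-methylphenyl in place of 3-hydroxyphenyl on a nitrogen on an aromatic ring. For the measured compounds named here, no measured step swaps a hydroxyl for a methyl here, so the step from compound 1 to compound 2 bears only loosely: it shows that the anilino substituent matters, and that compound 1 with 4-hydroxyphenyl sits below compound 2 with 3-hydroxyphenyl. The change to compound 3 both removes the hydroxyl and places the substituent as 4-methylphenyl, so direction is uncertain; a step of about a 1.9-fold lower number from compound 2 to compound 3 (0.27 log units; within the scatter) is expected, with wide bounds. Compound 3 is therefore estimated at 15000 nM, in the range 4000 nM to 60000 nM.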

Compound 3, concentration for 50% growth inhibition: 6100 nM
Compound 3: middle estimate off by 2.5-fold (0.39 log units), on the high side; low and high end bracket the measured number.
By their numbers in this assay, from the lowest: compounds 3 and 1 (each within the scatter of the next); then compound 2.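

The swap of methyl for hydroxy on an aromatic carbon can now be read directly: it gives a 1.5-fold lower number from compound 1 to compound 3 (0.16 log units; within the scatter) in this assay and does not separate 4-methylphenyl from 4-hydroxyphenyl. By contrast, a 4.6-fold lower number from compound 2 to compound 3 (0.66 log units; beyond the scatter) sets 4-methylphenyl apart from 3-hydroxyphenyl, so among these three compounds only compound 2, the one with 3-hydroxyphenyl, stands apart, and the hydroxy group itself is not needed to reach the level of compound 1. No supporting data accompany these numbers to explain the pattern.

Still open, as far as these compounds go, is whether 3-methylphenyl would track 3-hydroxyphenyl or 4-methylphenyl, which would separate the effect of the group from that of its place on the ring. Also open, from the compounds shown here alone, is how an amine or a carboxylic acid on the anilino ring would compare with hydroxy and methyl.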